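A few compounds are considered here, and "the series" means these few. Any claim that something is new, unique, unknown or untested is made for them only; others in the source may bear on it.

Compound 1 `O=c1cc(-c2ccccc2)oc2c(OCCCCNC3CCCCC3)c(O)cc(O)c12`: "not determined" (no result reported)
Compound 2 `CCN(CC)CCCOc1c(O)cc(O)c2c(=O)cc(-c3ccccc3)oc12`: > 100000 nM
Compound 3 `CC(C)NCCCCOc1c(O)cc(O)c2c(=O)cc(-c3ccccc3)oc12`: "not determined" (no result reported)

In a functional assay on A549 cells (Homo sapiens) for cytotoxicity, read by MTT assay, with a stated time of 48 h (a higher number here means a weaker inhibitor, a lower number a stronger inhibitor), compound 3 is reported as "not determined" (no result reported), so it offers no single number to start from. The only other result is for compound 2, whose > 100000 nM is a limit of the assay and not a number.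

Compound 4 `CN(C)CCCCOc1c(O)cc(O)c2c(=O)cc(-c3ccccc3)oc12` has yet to be measured. Its structure brings dimethylamino in place of isopropylamino on a saturated chain carbon, four bonds along the chain from an oxygen on an aromatic ring.

No measured step sizes this change, so no shift beyond the scatter is expected in this assay, and the expectation leans on (the limit of > 100000 nM in this assay, at which 1 of the 3 values shown sits). For compound 4 the expected value is 60000 nM, with an estimated range of 15000 nM to 100000 nM.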

Compound 4, half-maximal inhibitory concentration: > 100000 nM
Compound 4 was reported as a limit; the forecaster's own chance of this, stated with the estimate: 50%; at least 1.6-fold (0.22 log units) between middle value and limit.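

No step can be read from compound 2 to compound 4, because each result is a limit and not a number: the limit of > 100000 nM in this assay, at which 2 of the 4 values shown sit. Whether any compound shown reaches a readable value in this assay, and how their amine groups compare there, stays open.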